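A few compounds are considered here, and "the series" means these few. Any claim that something is new, unique, unknown or untested is made for them only; others in the source may bear on it.

In a functional assay on MT4 cells (Homo sapiens) for cytotoxicity, read by CellTiter-Glo, with a stated time of 5 days (a lower number here means that less compound is needed, a higher number that more compound is needed for the effect), compound 3 (`Cc1ccc(-c2c(C)n[nH]c2C)cc1S(=O)(=O)NC1CCCC1`) gives 5420 nM and compound 1 (`Cc1ccc(-c2c(C)noc2CO)cc1S(=O)(=O)NC1CCCC1`) gives 6820 nM, a pair separated only by a 1.3-fold lower number from compound 1 to compound 3 (0.10 log units; within the scatter). Compound 2 (`Cc1ccc(-c2cnoc2)cc1S(=O)(=O)NC1CCCC1`) gives 43200 nM, clearly apart from both. Compound 4 (`Cc1cc(-c2ccc(C)c(S(=O)(=O)NC3CCCC3)c2)cnn1`) differs from compound 3 by 6-methylpyridazin-4-yl in place of 3,5-dimethyl-1H-pyrazol-4-yl on an aromatic carbon: 6-methylpyridazin-4-yl in place of 3,5-dimethyl-1H-pyrazol-4-yl. The closest guides are an 8.0-fold lower number from compound 2 to compound 3 (0.90 log units; beyond the scatter) and a 6.3-fold higher number from compound 1 to compound 2 (0.80 log units; beyond the scatter), modest moves made by changing the group at this same place. Going by the values given here, no measured compound carries a six-membered ring there, so the direction is uncertain, but a modest rise is the likelier outcome. The expected step is a 3.3-fold higher number from compound 3 to compound 4 (0.52 log units; beyond the scatter), toward a higher number. For compound 4 the estimated value is 18000 nM, within an expected range of 5500 nM to 60000 nM.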

Compound 4, half-maximal effective concentration: 3760 nM
For compound 4 the middle estimate is 4.8-fold (0.68 log units) above the measured one; measured number outside the range, below it.
By their numbers in this assay, from the lowest: compounds 4, 3 and 1 (each within the scatter of the next); then compound 2.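

Swapping the five-membered ring for the six-membered 6-methylpyridazin-4-yl at this position changes little in this assay, with a 1.4-fold lower number from compound 3 to compound 4 (0.16 log units; within the scatter) and a 1.8-fold lower number from compound 1 to compound 4 (0.26 log units; within the scatter), both within the scatter. A five-membered ring is therefore not needed here, and the gap to the unmethylated ring remains wide, with an 11-fold lower number from compound 2 to compound 4 (1.06 log units; beyond the scatter). No measured evidence explains these results.

Going by these compounds, whether a plain phenyl ring, or a ring carrying an amine or a carboxylic acid, would behave the same remains open. So does the role of the methyl groups found on the ring in compound 1, compound 3 and compound 4 but not in compound 2.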